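A Third Methoxy Group on a Limit-Bound Compound

The source may hold more compounds than are shown below. What is called first, only, known or untested is meant among the compounds shown, and "the series" means these compounds.

Compound 1 `Cc1cc(O)c(C2=NN(c3ccc(S(N)(=O)=O)cc3)C(c3ccccc3Cl)C2)cc1Cl` was tested in a functional assay on Malme-3M cells (Homo sapiens) for antiproliferative activity, with a stated time of 48 h; on this read-out lower numbers stand for higher toxicity in this test and higher numbers for lower toxicity in this test. In this assay compound 1 gives only a limit, > 100000 nM, not a number. Compound 2 `COc1ccc(C2CC(c3cc(Cl)c(C)cc3O)=NN2c2ccc(S(N)(=O)=O)cc2)cc1OC` carries a 3,4-dimethoxyphenyl in place of the 2-chlorophenyl on a saturated ring carbon. In this assay compound 2 likewise reaches only a limit, > 100000 nM. The step that the two limits leave unreadable from compound 1 to compound 2 therefore cannot be read, because both values sit at the limit of > 100000 nM in this assay, at which 2 of the 2 values shown sit. Going by the values given here, compound 2 thus stands at the limit, together with the only other value shown. Compound 3 `COc1ccc(C2CC(c3cc(Cl)c(C)cc3O)=NN2c2ccc(S(N)(=O)=O)cc2)c(OC)c1OC` differs from compound 2 by methoxy in place of hydrogen on an aromatic carbon. Among the compounds with values here, the single measured step bears on this change only in that it yields no readable size at all. The expectation for compound 3 is therefore a step of a number no higher from compound 2 to compound 3 (the limit leaves the size open) of no size beyond the scatter, most likely ending again at a limit. Compound 3 is estimated at 100000 nM, within 30000 nM to 300000 nM.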

Compound 3, concentration lethal to 50% of the cells: 21400 nM
Compound 3: middle estimate off by 4.7-fold (0.67 log units), on the high side; measured number below the stated range.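

In this assay, going by these compounds alone, the methoxy on the aromatic carbon, ortho to a large group and ortho to a methoxy group, is the first change here to give a readable result: an at least 4.6-fold lower number from compound 2 to compound 3 (0.66 log units; beyond the scatter). Exchanging the 2-chlorophenyl on the saturated ring carbon for the 2,3,4-trimethoxyphenyl likewise gives an at least 4.6-fold lower number from compound 1 to compound 3 (0.66 log units; beyond the scatter), whereas the step to the 3,4-dimethoxyphenyl could not be read. Each of these sizes is only a minimum, and compound 3 is the only compound shown with a number rather than a limit: the limit of > 100000 nM in this assay, at which 2 of the 3 values shown sit.

On these data alone, it stays open whether another group on this aromatic carbon, such as an ethoxy, a hydroxyl or an amine, would also lower the number. Also open, as far as these compounds go, is whether methoxy would do the same on the 2-chlorophenyl of compound 1.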